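Working notes: from compound 3 to compound 4

The compounds below may be only part of what the source reports. "The series", "measured", "known", "first", "only" and "open" are said of these compounds alone.

Three compounds of the series have numbers in a functional assay on HT-29 cells (Homo sapiens) for cytotoxicity, read by sulforhodamine B assay; a higher number here means a weaker inhibitor of growth, a lower number a stronger inhibitor of growth. Compound 1 `O=c1oc2ccc(Cl)cc2cc1-c1cn2nc(-c3c([O-])[o+]nn3-c3ccc(Cl)cc3)sc2n1` gives 8 ug/mL. Compound 2 `O=c1oc2ccccc2cc1-c1cn2nc(-c3c([O-])[o+]nn3-c3ccc(Cl)cc3)sc2n1` gives 4 ug/mL. Compound 3 `COc1ccc(-n2n[o+]c([O-])c2-c2nn3cc(-c4cc5cc(Br)ccc5oc4=O)nc3s2)cc1` gives 3.04 ug/mL, the lowest of the three numbers; its gap to compound 2 is within the scatter, its gap to compound 1 is beyond it. Going by the values given here, the one single-point step measured so far is a 2.0-fold lower number from compound 1 to compound 2 (0.30 log units; within the scatter), which concerns the six-membered ring of the shared core rather than the aryl group on the charged ring.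

Compound 4 `O=c1oc2ccc(Br)cc2cc1-c1cn2nc(-c3c([O-])[o+]nn3-c3ccc(Cl)cc3)sc2n1` differs from compound 3 by chloro in place of methoxy on an aromatic carbon. Among the compounds with values here, no measured pair shows this change, so nothing directly bears on it; compounds 1 and 2, which both carry the 4-chlorophenyl group, sit within the scatter of compound 3 or close to it. The step of a 1.3-fold higher number from compound 3 to compound 4 (0.12 log units; within the scatter) is therefore expected to stay within the scatter, with no direction claimed. Compound 4 is estimated at 4 ug/mL in this assay, in the range 1.5 ug/mL to 10 ug/mL.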

Compound 4, concentration for 50% growth inhibition: 5.25 ug/mL
The estimate for compound 4 lay 1.3-fold (0.12 log units) below the measured number, within the range that was stated.
By their numbers in this assay, from the lowest: compounds 3, 2, 4 and 1 (each within the scatter of the next, the first and the last beyond it).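

Going by these compounds alone, the change from 4-methoxyphenyl to 4-chlorophenyl is the first measured at this position, and in this assay it gives (a 1.7-fold higher number from compound 3 to compound 4 (0.24 log units; within the scatter)), so the two groups are not separated here. With 4-chlorophenyl held, bromo on the shared core gives (a 1.3-fold higher number from compound 2 to compound 4 (0.12 log units; within the scatter)) against hydrogen and (a 1.5-fold lower number from compound 1 to compound 4 (0.18 log units; within the scatter)) against chloro, so hydrogen, chloro and bromo at that place are also not separated by any single step. Nothing measured on these compounds accounts for these steps.

On these data alone, it remains open whether an amine, a carboxylic acid or a longer alkoxy chain in place of chloro or methoxy would move the number beyond the scatter. The compounds shown also leave open whether the two places act independently.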